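Adding a Cyano Group to the Weakest Compound

The compounds below may be only part of what the source reports. "The series", "measured", "known", "first", "only" and "open" are said of these compounds alone.

So far, three compounds have been measured in an assay for inhibition of Tryptophan 2,3-dioxygenase (Homo sapiens), with stated times of 10 min and 60 min; a lower number here means a stronger inhibitor, a higher number a weaker inhibitor. Compound 1 `O=[N+]([O-])c1cccc(CNc2cc(Br)cc3[nH]ncc23)c1` gives 1600 nM and compound 3 `O=[N+]([O-])c1cc(Cl)ccc1CNc1cc(C(F)(F)F)cc2[nH]ncc12` gives 1700 nM. Compound 2 `O=[N+]([O-])c1ccccc1CNc1cccc2[nH]ncc12` gives 17000 nM, the highest of the three numbers and therefore the weakest inhibitor among them, since its gaps to compound 1 and to compound 3 both lie beyond the scatter. Compound 4 `N#Cc1cc(NCc2ccccc2[N+](=O)[O-])c2cn[nH]c2c1` is compound 2 with a single change: cyano in place of hydrogen on an aromatic carbon. Compound 1 and compound 3 each carry a group on the shared core where compound 2 carries hydrogen, and both give lower numbers, though compound 3 also differs on its other ring. The step of a 4.3-fold lower number from compound 2 to compound 4 (0.63 log units; beyond the scatter) is expected to lower the number beyond the scatter. Compound 4 is estimated at 4000 nM, with a range from 1500 nM to 12000 nM.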

Compound 4, half-maximal inhibitory concentration: > 100000 nM
Compound 4 ended at the assay's limit; the forecaster's own chance of this, stated with the estimate: 5%; middle value at least 25-fold (1.39 log units) from the limit.
By their numbers in this assay, from the lowest: compounds 1 and 3 (each within the scatter of the next); then compound 2. At a limit, above all of these: compound 4.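

In this assay, compound 4 gives > 100000 nM. This value is a limit of the assay, not a number: the limit of > 100000 nM in this assay, at which 1 of the 4 values shown sits.
Even so, the step of an at least 5.8-fold higher number from compound 2 to compound 4 (0.76 log units; beyond the scatter) is the first comparison here that isolates one change, and it shows that cyano in place of hydrogen at this place on the shared core gives a higher number, so a weaker inhibitor.

How far the number rises cannot be read from a limit. From the compounds shown here alone, whether other groups at this place, such as an amine or a carboxylic acid, also give a higher number stays open.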